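Rebuilding the Amide Aryl Group after Compound 3

The source may report more compounds than this note shows. Statements on the series, on what has been measured and on what is new or still open speak of the compounds shown alone.

Compound 1 `O=C(COc1ccc2cc(/C=C3/SC(=O)NC3=O)ccc2c1)Nc1ccc([N+](=O)[O-])cc1` gives in an assay on isolated protein for inhibition of histone deacetylase 8 (Homo sapiens), with a stated time of 1 h (on this read-out lower numbers stand for stronger inhibition and higher numbers for weaker inhibition), a value of 4000 nM, and compound 2 `O=C(COc1ccc2cc(/C=C3/SC(=O)NC3=O)ccc2c1)Nc1ccc(F)cc1` gives in this assay a value of 6600 nM; the step of a 1.7-fold higher number from compound 1 to compound 2 (0.22 log units; within the scatter) lies within the scatter. For the measured compounds named here, compound 3 `O=C(COc1ccc2cc(/C=C3/SC(=O)NC3=O)ccc2c1)Nc1c(F)cc(F)cc1Br` gives in this assay only > 50000 nM, which is a limit of the assay and not a number, so compound 3 stands as the one value at the limit of > 50000 nM in this assay, at which 1 of the 3 values shown sits. The steps of an at least 12-fold higher number from compound 1 to compound 3 (1.09 log units; beyond the scatter) and an at least 7.5-fold higher number from compound 2 to compound 3 (0.87 log units; beyond the scatter) were both beyond the scatter and both toward weaker inhibition. Compound 4 `O=C(COc1ccc2cc(/C=C3/SC(=O)NC3=O)ccc2c1)Nc1cccc(Cl)c1` carries the change (3-chlorophenyl in place of 2-bromo-4,6-difluorophenyl on an amide-type nitrogen), which replaces the aryl group that arrived with those two steps. Because the steps of an at least 12-fold higher number from compound 1 to compound 3 (1.09 log units; beyond the scatter) and an at least 7.5-fold higher number from compound 2 to compound 3 (0.87 log units; beyond the scatter) carried the loss, the step of an at least 6.2-fold lower number from compound 3 to compound 4 (0.79 log units; beyond the scatter) is expected to run the other way, toward stronger inhibition, and to be large. Compound 4 is therefore estimated at 8000 nM, expected to fall between 2500 nM and 30000 nM. Going by the values given here, no measured compound carries a 3-chlorophenyl, so the range is kept wide.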

Compound 4, half-maximal inhibitory concentration: > 50000 nM
Compound 4: a limit, no number; the forecaster's own chance of this, stated with the estimate: 10%; middle value at least 6.2-fold (0.79 log units) away from the limit.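

In this assay, the 3-chlorophenyl on the amide-type nitrogen also brings a clear loss, with an at least 7.5-fold higher number from compound 2 to compound 4 (0.87 log units; beyond the scatter) and an at least 12-fold higher number from compound 1 to compound 4 (1.09 log units; beyond the scatter), so the loss at this position is not confined to the 2-bromo-4,6-difluorophenyl group. Among the four aryl groups shown, only the 4-nitrophenyl of compound 1 and the 4-fluorophenyl of compound 2 give a number rather than a limit. Compound 4 gives only a limit of the assay, as compound 3 does, so the step between these two cannot be read: the limit of > 50000 nM in this assay, at which 2 of the 4 values shown sit.

As far as these compounds go, how compound 3 and compound 4 rank against each other stays open. So does whether a 4-chlorophenyl, a 4-aminophenyl or a 4-carboxyphenyl on the same nitrogen would give a number in the range of compound 1 and compound 2.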